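A few compounds are considered here, and "the series" means these few. Any claim that something is new, unique, unknown or untested is made for them only; others in the source may bear on it.

Measured compounds:
Compound 1, `Cc1ccc2nc(C(=O)Nc3c(F)cc(-c4cccc(F)c4)cc3F)c(C)c(O)c2c1`: in a functional assay on Hep 3B2 cells (Homo sapiens) for antiproliferative activity, read by MTT assay, with a stated time of 24 h, tested at 1.23 ug/mL (a higher number here means a stronger effect of the compound at the concentration tested, a lower number a weaker effect), compound 1 gives 11.2%.
Compound 2, `Cc1c(C(=O)Nc2c(F)cc(-c3cccc(F)c3)cc2F)nc2ccc(OC(F)(F)F)cc2c1O`: in this assay compound 2 gives 17.2%.
Compound 3, `Cc1ccc2nc(C(=O)Nc3c(F)cc(-c4cccc(F)c4)cc3F)c(C)c(C(=O)O)c2c1`: in this assay compound 3 gives 21.3%.

Compound 3 stands highest of the three numbers in this assay. For the measured compounds named here, its nearest neighbour is compound 2, whose number lies within the scatter of it, while compound 1 sits further off: the step of a number 10.1 percentage points higher from compound 1 to compound 3 (beyond the scatter) is the only change beyond the scatter in the set. The other measured step, a number 6 percentage points higher from compound 1 to compound 2 (within the scatter), stays within the scatter.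

Compound 4, `COc1ccc2nc(C(=O)Nc3c(F)cc(-c4cccc(F)c4)cc3F)c(C)c(C(=O)O)c2c1`, has not yet been measured. It differs from compound 3 in one place: methoxy in place of methyl on an aromatic carbon. Going by the values given here, the step that bears on this change is the one from compound 1 to compound 2, where a trifluoromethoxy took the place of a methyl on the same aromatic carbon of the shared core and the number moved only within the scatter. On that basis, no step beyond the scatter is expected in this assay from compound 3 to compound 4, and the estimate for the step is a number 0.7 percentage points higher from compound 3 to compound 4 (within the scatter). Compound 4 is therefore expected to give 22%, with a range from 10% to 34%.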

Compound 4, a percentage reported as inhibition, at one concentration (the size of the read-out at that concentration, not a potency): 1.05%
For compound 4 the middle estimate is 21 percentage points above the measured one; the whole stated range lies above it.
By their numbers in this assay, from the lowest: compound 4; then compounds 1, 2 and 3 (each within the scatter of the next, the first and the last beyond it).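

In this assay, the change from methyl to methoxy on this aromatic carbon gives a number 20.3 percentage points lower from compound 3 to compound 4 (beyond the scatter), so the position is not indifferent to what it carries, as the earlier step alone might have suggested. That earlier step, a number 6 percentage points higher from compound 1 to compound 2 (within the scatter), put trifluoromethoxy at the same carbon of a compound with hydroxy rather than carboxy on the core, so the two steps differ in both the entering group and the setting. No measurement here bears on why the number falls with methoxy. The compounds shown leave open whether the fall belongs to methoxy itself or to methoxy alongside carboxy, since the two groups are never each paired across both settings. They also leave open how an amine, a chlorine or a longer alkoxy chain at this carbon would behave.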